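Notes on a nitrile-bearing series in glutathione reductase inhibition

The source may report more compounds than this note shows. Statements on the series, on what has been measured and on what is new or still open speak of the compounds shown alone.

All values below come from an assay on isolated protein for inhibition of glutathione reductase, mitochondrial (Homo sapiens), using NADPH, with a stated time of 15 min; a lower number here means a stronger inhibitor, a higher number a weaker inhibitor.
- Compound 1, `[O-][n+]1onc(-c2ccccc2)c1CO`: in this assay compound 1 reaches only a limit, > 50000 nM.
- Compound 2, `N#Cc1c(-c2cccc(Br)c2)no[n+]1[O-]`: in this assay compound 2 likewise reaches only a limit, > 50000 nM.
- Compound 3, `N#Cc1c(-c2cccc(Cl)c2)no[n+]1[O-]`: in this assay compound 3 gives 35700 nM.

Among the compounds with values here, compound 3 thus holds the only number; the two other values are limits, as stated in the limit of > 50000 nM in this assay, at which 2 of the 3 values shown sit. Within the data shown here, the single measured step, an at least 1.4-fold lower number from compound 2 to compound 3 (0.14 log units; that floor lies within the scatter), is bounded only on one side and its floor lies within the scatter.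

Compound 4, `COc1cccc(-c2no[n+]([O-])c2C#N)c1`, differs from compound 3 by methoxy in place of chloro on an aromatic carbon. Among the measured compounds shown here, no measured step involves a methoxy group. For the measured compounds named here, the only change measured at the same aromatic carbon, an at least 1.4-fold lower number from compound 2 to compound 3 (0.14 log units; that floor lies within the scatter), barely moved the number, and it is the only comparison available for the step from compound 3 to compound 4 in this assay. Compound 4 is therefore expected to stay near compound 3 or drift back toward the limit, with a 1.3-fold higher number from compound 3 to compound 4 (0.10 log units; within the scatter) as the expected step. The estimate for compound 4 is 45000 nM, expected between 18000 nM and 110000 nM.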

Compound 4, half-maximal inhibitory concentration: > 50000 nM
Compound 4: only a limit was reported; the forecaster's own chance of this, stated with the estimate: 50%; middle value at least 1.1-fold (0.04 log units) from the limit.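

In this assay, methoxy in place of chloro on the aromatic carbon gives an at least 1.4-fold higher number from compound 3 to compound 4 (0.14 log units; that floor lies within the scatter), so a second replacement for chloro at this carbon, after bromo, also fails to yield a number, although the size of the step remains bounded on one side only. The step from compound 2 to compound 4 cannot be read, as both values are limits, so bromo and methoxy cannot be ranked against each other. Compound 3 remains the only compound with a number, and the series now sits largely at a single limit: the limit of > 50000 nM in this assay, at which 3 of the 4 values shown sit.

As far as these compounds go, it remains open whether an amine or a carboxylic acid in place of chloro would give a number clearly beyond the scatter from compound 3. Also open, from the compounds shown here alone, is what a carboxamide in place of the nitrile would do on the shared core.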